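A few compounds are considered here, and "the series" means these few. Any claim that something is new, unique, unknown or untested is made for them only; others in the source may bear on it.

Working notes on the series.

Two compounds of the shared core have numbers in a functional assay on K562/Adr cells (Homo sapiens) for inhibition, read by MTT assay, with a stated time of 48 h, tested at 30 uM; a higher number here means more inhibition at the concentration tested (going by the name of the read-out), a lower number less inhibition. Compound 1 `CC(C)(C)OC(=O)N1C[C@@H](n2cc(-c3ccc(N)nc3)nn2)C[C@H]1C(=O)Nc1ccc(Cl)c(C(F)(F)F)c1` gives 48.6% in this assay. Compound 2 `CC(C)(C)OC(=O)N1C[C@@H](n2cc(-c3ccc4c(N)n[nH]c4c3)nn2)C[C@H]1C(=O)Nc1ccc(Cl)c(C(F)(F)F)c1` gives 37.1% in this assay, the lowest of the two numbers shown; the one step measured, a number 11.5 percentage points lower from compound 1 to compound 2 (beyond the scatter), is the only comparison available and concerns the aromatic carbon, not the amide side.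

Compound 3 `CC(C)(C)OC(=O)N1C[C@@H](n2cc(-c3ccc4c(N)n[nH]c4c3)nn2)C[C@H]1C(=O)Nc1ccc(Cl)cc1Cl` is not yet measured. It differs from compound 2 by 2,4-dichlorophenyl in place of 4-chloro-3-(trifluoromethyl)phenyl on an amide-type nitrogen. Going by the values given here, no measured step touches the amide-type nitrogen, so the step from compound 1 to compound 2 bears on it only in showing that a single change of one ring elsewhere in the core moved this assay by a modest amount. With nothing to anchor the direction, the expectation for compound 3 is a small step at most, a number 5.1 percentage points lower from compound 2 to compound 3 (within the scatter), not clearly beyond the scatter and set slightly lower on the strength of the series as a whole. Compound 3 is therefore estimated at 32% in this assay, with a range from 15% to 50%.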

Compound 3, a percentage reported as inhibition, at one concentration (the size of the read-out at that concentration, not a potency): 25.6%
Compound 3: the middle estimate sits 6.4 percentage points above what was measured; the measured number falls inside the stated range.
By their numbers in this assay, from the lowest: compound 3; then compound 2; then compound 1.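

In this assay the amide-type nitrogen now has a measured step of its own: 2,4-dichlorophenyl in place of 4-chloro-3-(trifluoromethyl)phenyl gives a number 11.5 percentage points lower from compound 2 to compound 3 (beyond the scatter) and so shows that this read-out responds to the aryl group at this place, which the earlier pair could not show. The step has the same printed size as a number 11.5 percentage points lower from compound 1 to compound 2 (beyond the scatter) and the same direction, so a single change at either of the two places has now moved the number beyond the scatter, with each change seen only once. Nothing measured here accounts for the lower number at the amide-type nitrogen.

The change removes the trifluoromethyl group and brings in a second chlorine in one move, so the compounds shown do not separate these two parts of the change, and they do not show whether the step holds with the 6-aminopyridin-3-yl group on the aromatic carbon. As far as these compounds go, how an unsubstituted phenyl, or a ring carrying a nitrile or a methoxy group, would read on this nitrogen remains open.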